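Ester Substituent and Plasma Half-Life: Ethyl to Cyclobutyl

The source may report more compounds than this note shows. Statements on the series, on what has been measured and on what is new or still open speak of the compounds shown alone.

Measured so far:
compound 1 `CCOC(=O)/C=C/[C@H](C[C@@H]1CCNC1=O)NC(=O)[C@H](CC)n1cccc(NC(=O)c2cc(C)on2)c1=O`: 5.6 h
compound 2 `C#CC[C@@H](C(=O)N[C@H](/C=C/C(=O)OC1CCCC1)C[C@@H]1CCNC1=O)n1cccc(NC(=O)c2cc(C)on2)c1=O`: 12.5 h
compound 3 `C#CC[C@@H](C(=O)N[C@H](/C=C/C(=O)OCc1ccccc1)C[C@@H]1CCNC1=O)n1cccc(NC(=O)c2cc(C)on2)c1=O`: 4.3 h

In an ADME assay on the whole organism (plasma) for pharmacokinetics, with Homo sapiens as the target (a higher number here means that the compound lasts longer, a lower number that the compound disappears faster), compound 1 gives 5.6 h, the second highest of the three numbers; compound 3 lies within the scatter of it, while compound 2 stands beyond the scatter above it. Compound 4 `CC[C@@H](C(=O)N[C@H](/C=C/C(=O)OC1CCC1)C[C@@H]1CCNC1=O)n1cccc(NC(=O)c2cc(C)on2)c1=O` differs from compound 1 in one place: cyclobutyl in place of ethyl on an oxygen next to a carbonyl group. Going by the values given here, the one step at this place is a 2.9-fold lower number from compound 2 to compound 3 (0.46 log units; beyond the scatter), which shows that a change of the group on this oxygen can shift this assay modestly. Compound 2, with cyclopentyl there, holds the highest number, although it also differs from compound 1 in a second place. A modest rise is therefore expected: a 1.4-fold higher number from compound 1 to compound 4 (0.15 log units; within the scatter). Compound 4 is estimated at 8 h, between 4 h and 16 h.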

Compound 4, half-life in the Homo sapiens assay: 9.2 h
Compound 4: middle estimate off by 1.2-fold (0.06 log units), on the low side; low and high end bracket the measured number.
By their numbers in the Homo sapiens assay, from the lowest: compounds 3, 1, 4 and 2 (each within the scatter of the next, the first and the last beyond it).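

In the Homo sapiens assay, the swap of ethyl for cyclobutyl gives a 1.6-fold higher number from compound 1 to compound 4 (0.22 log units; within the scatter), so this change alone does not separate the two compounds on half-life. In a physicochemical assay for solubility, measured as thermodynamic solubility (on this read-out lower numbers stand for lower solubility and higher numbers for higher solubility), compound 1 gives 38 ug/mL and compound 4 gives 192 ug/mL. This position therefore also bears on solubility, where cyclobutyl in place of ethyl leads to a step beyond the scatter: the measured solubility of compound 1, 38 ug/mL, and of compound 4, 192 ug/mL, a 5.1-fold higher number (0.70 log units; beyond the scatter)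

On these data alone, whether the ring itself matters remains open, since a single pair cannot separate ring from carbon count. An isopropyl group or a longer chain on this oxygen could test that.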